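This account rests on a few compounds, and the source may have more. Where it says the series, first, only, none or still open, it means among the compounds named here.

Working notes on the series, read in a functional assay on HepG2 cells (Homo sapiens) for antiproliferative activity, read by sulforhodamine B assay, with a stated time of 48 h; on this read-out higher numbers stand for weaker inhibition and lower numbers for stronger inhibition. Compound 1 (`COc1cc(OC)c(/C=C/C(=O)C(=Cc2ccc(O)c(F)c2)C(=O)/C=C/c2c(OC)cc(OC)cc2OC)c(OC)c1`) gives 810 nM and compound 2 (`COc1cc(OC)c(/C=C/C(=O)C(=Cc2cc(Br)c(O)c(OC)c2)C(=O)/C=C/c2c(OC)cc(OC)cc2OC)c(OC)c1`) gives 660 nM. Among the compounds with values here, the only measured step is a 1.2-fold lower number from compound 1 to compound 2 (0.09 log units; within the scatter). Compound 2 therefore stands level with compound 1 on these numbers, and neither can be ranked above the other.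

The next compound is compound 3 (`COc1cc(OC)c(/C=C/C(=O)C(=Cc2cc(OC)c(O)c(OC)c2)C(=O)/C=C/c2c(OC)cc(OC)cc2OC)c(OC)c1`), with methoxy in place of bromo on an aromatic carbon. The same difference reads 3-bromo-4-hydroxy-5-methoxyphenyl to 4-hydroxy-3,5-dimethoxyphenyl.

Within the data shown here, no measured step exchanges these two groups directly. Among the measured compounds shown here, the one step that bears on the change is a 1.2-fold lower number from compound 1 to compound 2 (0.09 log units; within the scatter), which swaps 3-fluoro-4-hydroxyphenyl for 3-bromo-4-hydroxy-5-methoxyphenyl at the same place on the shared core. That step is small, but it is only indirect evidence. No step beyond the scatter is expected in this assay, in either direction, although two measured compounds give thin support. The estimated step is a 1.1-fold higher number from compound 2 to compound 3 (0.03 log units; within the scatter). For compound 3 the expected value is 700 nM, with an estimated range of 280 nM to 1800 nM.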

Compound 3, half-maximal inhibitory concentration: 510 nM
Compound 3: middle estimate off by 1.4-fold (0.14 log units), on the high side; measured number inside the range.
By their numbers in this assay, from the lowest: compounds 3, 2 and 1 (each within the scatter of the next).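

In this assay, methoxy in place of bromo on this aromatic carbon, ortho to a hydroxy group, gives a 1.3-fold lower number from compound 2 to compound 3 (0.11 log units; within the scatter), so this position accepts either group without a step that can be read, even though methoxy adds a hydrogen-bond acceptor that bromo lacks. The wider exchange of 3-fluoro-4-hydroxyphenyl for 4-hydroxy-3,5-dimethoxyphenyl gives a 1.6-fold lower number from compound 1 to compound 3 (0.20 log units; within the scatter), which places all three substituted phenyl groups level with one another and gives no ranking among them. No measurement is available that could account for these results.

On these data alone, all three compounds keep the hydroxy group on this ring and share the rest of the core, so what either part contributes to the read-out remains open. Within the data shown here, it also remains open whether an amine or a carboxylic acid on this aromatic carbon, or a longer alkoxy chain such as butoxy, would stay level with methoxy and bromo or produce the first step beyond the scatter.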